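The compounds below may be only part of what the source reports. "The series", "measured", "known", "first", "only" and "open" are said of these compounds alone.

Measured so far in a functional assay on HCT-116 cells (Homo sapiens) for inhibition, read by sulforhodamine B assay, with a stated time of 48 h, tested at 10 uM; a lower number here means less inhibition, a higher number more inhibition at the concentration tested (going by the name of the read-out):
compound 1 `COc1ccc(-c2cn3ccnc3c(-c3ccc4ncn(C5CCCCC5)c4c3)n2)cc1` gives 91.3%
compound 2 `Fc1ccc(-c2cn3ccnc3c(-c3ccc4ncn(C5CCCCC5)c4c3)n2)cc1` gives 18%
compound 3 `COc1ccccc1-c1cn2ccnc2c(-c2ccc3ncn(C4CCCCC4)c3c2)n1` gives 28.3%

Compound 4 `Fc1ccccc1-c1cn2ccnc2c(-c2ccc3ncn(C4CCCCC4)c3c2)n1` remains to be measured. It differs from compound 3 by fluoro in place of methoxy on an aromatic carbon. The same kind of change was made from compound 1 to compound 2, namely (fluoro in place of methoxy on an aromatic carbon), but there the place is para to a large group, while in compound 4 it is ortho to a large group. That earlier step was a number 73.3 percentage points lower from compound 1 to compound 2 (beyond the scatter). The cores of compound 1 and compound 3 differ by 2-methoxyphenyl in place of 4-methoxyphenyl on an aromatic carbon, which gave a number 63 percentage points lower from compound 1 to compound 3 (beyond the scatter), and from compound 2 to compound 3 the change was a number 10.3 percentage points higher from compound 2 to compound 3 (beyond the scatter). Because compound 3 already stands at 28.3%, a fall as deep as the earlier one cannot recur. The step from compound 3 to compound 4 is therefore expected to be a number 13.3 percentage points lower from compound 3 to compound 4 (beyond the scatter). Compound 4 is estimated at 15%, likely between 0% and 35%.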

Compound 4, a percentage reported as inhibition, at one concentration (the size of the read-out at that concentration, not a potency): 25.8%
Compound 4: the middle estimate sits 10.8 percentage points below what was measured, and the stated range covers the measured number.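

In this assay, fluoro in place of methoxy did not carry the same size of step from one core to the other: the same change on two cores in this assay, a number 73.3 percentage points lower (beyond the scatter) from compound 1 to compound 2 and a number 2.5 percentage points lower (within the scatter) from compound 3 to compound 4, 70.8 percentage points apart, beyond the scatter of two such steps

On the core of compound 3, the change gave a number 2.5 percentage points lower from compound 3 to compound 4 (within the scatter); 2-fluorophenyl in place of 4-fluorophenyl gave a number 7.8 percentage points higher from compound 2 to compound 4 (within the scatter), and 2-fluorophenyl in place of 4-methoxyphenyl gave a number 65.5 percentage points lower from compound 1 to compound 4 (beyond the scatter). Going by these compounds alone, this shows that the large fall seen on the core of compound 1 cannot be assumed on another core, but with only two such pairs it does not show how the change would behave on any further core, nor why the steps differ.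

The compounds shown leave open whether another group in the place of the methoxy of compound 1, such as ethoxy, an amine or a carboxylic acid, would keep a number near that of compound 1, 91.3%.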